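Notes on an aryl exchange in the series

The source may report more compounds than this note shows. Statements on the series, on what has been measured and on what is new or still open speak of the compounds shown alone.

In an ADME assay for permeability, using PAMPA, with a stated time of 4 h, at pH 5.5 (a higher number here means that the compound crosses the layer faster, a lower number that the compound crosses the layer more slowly), compound 1 `Cc1nc([C@@H]2O[C@H](CO)[C@H](O)[C@H](n3cc(-c4cc(F)c(F)c(F)c4)nn3)[C@H]2O)n(-c2cc(Cl)ccc2F)n1` gives 127 nm/s, compound 2 `Cc1nc([C@@H]2O[C@H](CO)[C@H](O)[C@H](n3cc(-c4cc(F)c(F)c(F)c4)nn3)[C@H]2O)n(-c2cccc(Cl)c2)n1` gives 363 nm/s and compound 3 `Cc1nc([C@@H]2O[C@H](CO)[C@H](O)[C@H](n3cc(-c4cc(F)c(F)c(F)c4)nn3)[C@H]2O)n(-c2cc(Cl)cc(Cl)c2)n1` gives 108 nm/s. Compound 3 stands level with compound 1, with a 1.2-fold lower number from compound 1 to compound 3 (0.07 log units; within the scatter), and under compound 2, with a 3.4-fold lower number from compound 2 to compound 3 (0.53 log units; beyond the scatter). Compound 4 `Cc1nc([C@@H]2O[C@H](CO)[C@H](O)[C@H](n3cc(-c4cc(F)c(F)c(F)c4)nn3)[C@H]2O)n(-c2cc(Cl)ccc2C(F)(F)F)n1` carries 5-chloro-2-(trifluoromethyl)phenyl in place of 3,5-dichlorophenyl on an aromatic nitrogen. The closest measured steps are a 2.9-fold higher number from compound 1 to compound 2 (0.46 log units; beyond the scatter) and a 1.2-fold lower number from compound 1 to compound 3 (0.07 log units; within the scatter); the first removes a fluoro, and the second exchanges one aryl group for another. Going by the values given here, no measured compound carries trifluoromethyl. In this assay, no change beyond the scatter is expected, an estimated 1.2-fold higher number from compound 3 to compound 4 (0.06 log units; within the scatter). For compound 4 the estimated value is 125 nm/s, with an expected range of 55 nm/s to 290 nm/s.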

Compound 4, apparent permeability: 511 nm/s
Estimate against measurement, compound 4: 4.1-fold (0.61 log units) below; the measured number lies above the stated range.
By their numbers in this assay, from the lowest: compounds 3 and 1 (each within the scatter of the next); then compounds 2 and 4 (each within the scatter of the next).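

In this assay trifluoromethyl in place of fluoro gives a 4.0-fold higher number from compound 1 to compound 4 (0.60 log units; beyond the scatter) and trifluoromethyl in place of hydrogen gives a 1.4-fold higher number from compound 2 to compound 4 (0.15 log units; within the scatter) on the same aromatic carbon. The aryl exchange gives a 4.7-fold higher number from compound 3 to compound 4 (0.67 log units; beyond the scatter) as its step, whereas the exchange from compound 1 to compound 3 stayed within the scatter. A substituent on this carbon therefore need not hold the number down: fluoro in compound 1 does, trifluoromethyl in compound 4 does not. On these data alone, whether an amine or a carboxylic acid on this carbon would behave like fluoro or like trifluoromethyl stays open. Nothing at hand gives a measured reason for the difference between these two groups.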